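The compounds below may be only part of what the source reports. "The series", "measured", "known", "first", "only" and "open" are said of these compounds alone.

Working notes on the series. The shared core is that of compound 1 `Cc1ccc(-c2nn(-c3ccccc3)cc2CNc2ccccc2)cc1`; compound 2 `Cc1ccc(-c2nn(-c3ccccc3)cc2CNc2ccc(Br)cc2)cc1` and compound 3 `Cc1ccc(-c2nn(-c3ccccc3)cc2CNc2ccc(C(F)(F)F)cc2)cc1` differ from it only in the steps noted below. In an ADME assay on MT4 cells (Homo sapiens) for cytotoxicity, read by MTT assay, with a stated time of 96 h (on this read-out lower numbers stand for higher toxicity in this test and higher numbers for lower toxicity in this test), compound 1 gives > 100000 nM, which is a limit of the assay and not a number. In this assay compound 2 gives > 100000 nM, again a limit. In this assay compound 3 gives > 100000 nM, also a limit. Compound 2 therefore stands only at a limit, the two further values shown are limits as well, and (the limit of > 100000 nM in this assay, at which 3 of the 3 values shown sit). The steps a step that the two limits leave unreadable from compound 1 to compound 2, a step that the two limits leave unreadable from compound 1 to compound 3 and a step that the two limits leave unreadable from compound 2 to compound 3 accordingly cannot be given a size or a direction.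

The next compound, compound 4 `Brc1ccc(NCc2cn(-c3ccccc3)nc2-c2ccc(Br)cc2)cc1`, differs from compound 2 by bromo in place of methyl on an aromatic carbon. The measured steps that bear on it are those three, each left unreadable between two limits, so nothing measured points to a direction or a size. The expectation for this assay is a step of a number no higher from compound 2 to compound 4 (the limit leaves the size open) of no size beyond the scatter, with the read-out most likely returning only a limit once more. Compound 4 is estimated at 100000 nM, with a range from 40000 nM to 300000 nM.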

Compound 4, half-maximal cytotoxic concentration: > 100000 nM
Compound 4: no number, only a limit (the forecaster's own chance of this, stated with the estimate: 80%); the middle value sits exactly at the limit.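

In this assay compound 4 gives > 100000 nM, again a limit of the assay and not a number. No new step can be read between compound 2 and compound 4, so bromo in place of methyl gains neither size nor direction. The compounds shown leave open whether any change on the shared core would yield a measurable number, because all of them stand at one limit: the limit of > 100000 nM in this assay, at which 4 of the 4 values shown sit.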